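Replacing a chloro with a trifluoromethyl-pyridyl ring

The source may report more compounds than this note shows. Statements on the series, on what has been measured and on what is new or still open speak of the compounds shown alone.

Of the compounds shown here, three sharing one core have been measured in an assay on a protein complex for inhibition of ubiquitin carboxyl-terminal hydrolase 1/WD repeat-containing protein 48 (Homo sapiens), read by fluorescence; a higher number here means a weaker inhibitor, a lower number a stronger inhibitor. Compound 1 `Fc1ccc(CNc2nc(-c3ccccc3C(F)(F)F)nc3ccccc23)cc1` gives 3400 nM. Compound 2 `FC(F)(F)c1ccccc1-c1nc(NCc2ccc(Cl)cc2)c2ccccc2n1` gives 4800 nM. Compound 3 `FC(F)(F)c1ccccc1-c1nc(NCc2ccc(-c3cncnc3)cc2)c2ccccc2n1` gives 3000 nM. Compound 2 has the highest number of the three, but its separation from the others is small: the step of a 1.4-fold higher number from compound 1 to compound 2 (0.15 log units; within the scatter) and the step of a 1.6-fold lower number from compound 2 to compound 3 (0.20 log units; within the scatter) both lie within the scatter, so no ordering among them can be claimed.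

Compound 4 `FC(F)(F)c1cc(-c2ccc(CNc3nc(-c4ccccc4C(F)(F)F)nc4ccccc34)cc2)ccn1` is the next compound to be tested in this assay . It differs from compound 2 by a single change: 2-(trifluoromethyl)pyridin-4-yl in place of chloro on an aromatic carbon.

The measured step that bears most directly on this change is a 1.6-fold lower number from compound 2 to compound 3 (0.20 log units; within the scatter), where a chloro was likewise swapped for a six-membered aromatic ring containing nitrogen, with no movement beyond the scatter. The step of a 1.1-fold lower number from compound 1 to compound 3 (0.05 log units; within the scatter) tells the same story for a fluoro. On that basis a step of a 1.6-fold lower number from compound 2 to compound 4 (0.20 log units; within the scatter) is expected, that is, no change beyond the scatter. For compound 4 the estimated value in this assay is 3000 nM, with a range from 1200 nM to 8000 nM.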

Compound 4, half-maximal inhibitory concentration: 4900 nM
Beside the measured number, compound 4's estimate is 1.6-fold (0.21 log units) below it; low and high end bracket the measured number.
By their numbers in this assay, from the lowest: compounds 3, 1, 2 and 4 (each within the scatter of the next).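

In this assay, the aromatic carbon para to a large group now carries 2-(trifluoromethyl)pyridin-4-yl, a group of 10 heavy atoms, in place of a chloro, yet the step of a 1.0-fold higher number from compound 2 to compound 4 (0.01 log units; within the scatter) stays within the scatter. The comparison with the small fluoro gives the same reading, with a 1.4-fold higher number from compound 1 to compound 4 (0.16 log units; within the scatter), and so does the comparison between the two aromatic rings, with a 1.6-fold higher number from compound 3 to compound 4 (0.21 log units; within the scatter). Compound 4 therefore extends what compounds 1, 2 and 3 showed: a much larger ring bearing a trifluoromethyl group can sit at this position without a change beyond the scatter, and none of the four compounds goes against this.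

No measurement shown here explains why the numbers stay so close together. It also remains open whether an amine, a carboxylic acid or a longer chain at this position would shift the number beyond the scatter, as the groups shown so far are only halogens and aromatic rings.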